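A few compounds are considered here, and "the series" means these few. Any claim that something is new, unique, unknown or untested is made for them only; others in the source may bear on it.

Working notes on the series, read-out in an ADME assay on BJ cells (Homo sapiens) for cytotoxicity, with a stated time of 72 h; on this read-out lower numbers stand for an effect already at smaller amounts and higher numbers for an effect only at larger amounts of compound:
- compound 1 `C=C[C@@](C)(/C=C/c1ccc(OC)cc1)CCC=C(C)C` gives > 36600 nM
- compound 2 `CC(C)=CCC[C@@](C)(/C=C/c1ccc(C)cc1)/C=C/c1ccc(O)cc1` gives > 36600 nM

In this assay compound 1 gives > 36600 nM, and this is a limit of the assay, not a number. Compound 2 likewise has only a limit. Among the measured compounds shown here, the series so far therefore shows only (the limit of > 36600 nM in this assay, at which 2 of the 2 values shown sit), and no measured step is available to give a scale.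

The next compound is compound 3 `C=C[C@@](C)(/C=C/c1ccc(Nc2ccc(OC)cc2)cc1)CCC=C(C)C`, which has (4-methoxyphenyl)amino in place of methoxy on an aromatic carbon of compound 1, para to a large group: (4-methoxyphenyl)amino in place of methoxy on an aromatic carbon.

With only a limit as its starting point, the step can be expected only in rough terms. A moderate move toward lower numbers is expected, meaning an effect at smaller amounts, although a further limit result is about as likely. The estimated change is an at least 1.3-fold lower number from compound 1 to compound 3 (0.11 log units; that floor lies within the scatter). For compound 3 the expected value is 28000 nM, with an estimated range from 9000 nM to 60000 nM.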

Compound 3, half-maximal effective concentration: > 36600 nM
Compound 3: no number, only a limit; the forecaster's own chance of this, stated with the estimate: 50%; at least 1.3-fold (0.11 log units) between middle value and limit.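

In this assay compound 3 gives > 36600 nM, which is a limit of the assay and not a number. Among the compounds shown here, compound 1 also has only a limit, so no step from compound 1 to compound 3 can be read. The series so far shows only: the limit of > 36600 nM in this assay, at which 3 of the 3 values shown sit.

The compounds shown leave open whether (4-methoxyphenyl)amino in place of methoxy changes this read-out at all.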